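The source may hold more compounds than are shown below. What is called first, only, known or untested is meant among the compounds shown, and "the series" means these compounds.

Among the measured compounds shown here, compound 2 `CC1=CC[C@H](C(C)(C)NC(=S)N/N=C/c2ccc(Cl)cc2)CC1` is the one compound in this set with a plain number to its name: in a functional assay on NCI/ADR-RES cells (Homo sapiens) for inhibition, read by sulforhodamine B assay, with a stated time of 48 h (a higher number here means a weaker inhibitor of growth, a lower number a stronger inhibitor of growth), compound 2 gives 65200 nM. Compound 1 `CC1=CC[C@H](C(C)(C)NC(=S)N/N=C/c2ccc(F)cc2)CC1` reaches only the limit of the assay, (the limit of > 100000 nM in this assay, at which 1 of the 2 values shown sits), and in this assay compound 1 gives > 100000 nM, which is a limit rather than a number. For the measured compounds named here, the only measured step is therefore an at least 1.5-fold lower number from compound 1 to compound 2 (0.18 log units; that floor lies within the scatter), and its floor sits within the scatter, so no firm direction can be read from it.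

Compound 3 `CC1=CC[C@H](C(C)(C)NC(=S)N/N=C/c2ccc[nH]2)CC1` changes something else altogether: 1H-pyrrol-2-yl in place of 4-chlorophenyl on a carbon with a double bond to nitrogen. Going by the values given here, no measured step exchanges the whole ring, so the step of an at least 1.5-fold lower number from compound 1 to compound 2 (0.18 log units; that floor lies within the scatter) carries little weight for this change, and compound 2 already sits close to the limit of this assay. A change of this kind is expected to leave compound 3 about as weak as compound 2, an expected step of a 1.5-fold higher number from compound 2 to compound 3 (0.19 log units; within the scatter). The estimate for compound 3 in this assay is 100000 nM, with a range from 30000 nM to 300000 nM, and a fair chance that only a limit is reported.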

Compound 3, concentration for 50% growth inhibition: 78000 nM
Estimate against measurement, compound 3: 1.3-fold (0.11 log units) above; the range from low to high includes it.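

In this assay, replacing the whole aromatic ring on a carbon with a double bond to nitrogen gives a 1.2-fold higher number from compound 2 to compound 3 (0.08 log units; within the scatter). Among the compounds shown here, this is the first comparison in the set between two plain numbers, and it shows that 1H-pyrrol-2-yl and 4-chlorophenyl cannot be told apart here, even though the entering ring is five-membered, has fewer heavy atoms and carries a hydrogen-bond donor. The other comparison gives an at least 1.2-fold lower number from compound 1 to compound 3 (0.10 log units; that floor lies within the scatter), which is only a floor and sets no direction, and the value of compound 1 behind it is a limit: the limit of > 100000 nM in this assay, at which 1 of the 3 values shown sits.

As far as these compounds go, all three compounds carry a single aromatic ring at this place, so it remains open whether a saturated cyclohexyl group, or a phenyl ring bearing a dimethylamino group or a carboxylic acid, would bring the number well down from the level of compound 2 and compound 3. From the compounds shown here alone, all three also share the same core, and what a change there would do to growth inhibition stays open as well.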